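Dimethoxyphenyl in place of isopentyloxy on a TRPV1 antagonist scaffold

The compounds below may be only part of what the source reports. "The series", "measured", "known", "first", "only" and "open" are said of these compounds alone.

Measured compounds:
compound 1, `CC(C(=O)NCc1ccc(C(F)(F)F)cc1N1CCC(Cc2ccc(F)cc2)CC1)c1ccc(NS(C)(=O)=O)c(F)c1`: 0.4 nM
compound 2, `CC(C)CCOc1cc(C(F)(F)F)ccc1CNC(=O)C(C)c1ccc(NS(C)(=O)=O)c(F)c1`: 0.5 nM

In an assay on CHO cells for antagonist activity at transient receptor potential cation channel subfamily V member 1 (Homo sapiens), read by FLIPR (a higher number here means a weaker inhibitor, a lower number a stronger inhibitor), compound 1 gives 0.4 nM and compound 2 gives 0.5 nM. Compound 2 holds the higher of the two numbers, but the gap to compound 1 lies within the scatter, so the two cannot be ranked. Compound 3, `COc1ccc(-c2cc(C(F)(F)F)ccc2CNC(=O)C(C)c2ccc(NS(C)(=O)=O)c(F)c2)cc1OC`, differs from compound 2 in one place: 3,4-dimethoxyphenyl in place of isopentyloxy on an aromatic carbon. For the measured compounds named here, no step between measured compounds is available, so the expectation rests only on compound 1 and compound 2, which carry two quite different groups at this position yet give closely similar values in this assay. On that basis compound 3 is expected to show a modest rise in number, a 4.0-fold higher number from compound 2 to compound 3 (0.60 log units; beyond the scatter), possibly no larger than the scatter. Compound 3 is estimated at 2 nM, within a range of 0.4 nM to 12 nM.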

Compound 3, inhibition constant: 8.6 nM
Compound 3: the middle estimate sits 4.3-fold (0.63 log units) below what was measured; low and high end bracket the measured number.
By their numbers in this assay, from the lowest: compounds 1 and 2 (each within the scatter of the next); then compound 3.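

In this assay, placing 3,4-dimethoxyphenyl in place of isopentyloxy on this aromatic carbon gives a 17-fold higher number from compound 2 to compound 3 (1.24 log units; beyond the scatter), so this position is not indifferent to the group it carries, even though compound 1 and compound 2 hold two quite different groups here and cannot be ranked. Among the three compounds, only compound 3 has a six-membered aromatic ring of carbon only on this carbon, and it also has the highest number. No measurement here accounts for the size of this step.

The compounds shown leave open whether the step follows from the aromatic ring itself or from its two methoxy groups, a question that a plain phenyl group or a phenyl group with one methoxy would address. They also leave open how a shorter ether such as ethoxy would fare at this position.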